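The source may hold more compounds than are shown below. What is called first, only, known or untested is meant among the compounds shown, and "the series" means these compounds.

Compound 1 `CN1C/C(=C\c2cccnc2)C(=O)/C(=C/c2ccccc2C(F)(F)F)C1` gives 2550 nM
Compound 2 `O=C1/C(=C/c2cccnc2)CNC/C1=C\c1ccccc1C(F)(F)F` gives 5020 nM

In a functional assay on HepG2 cells (Homo sapiens) for cytotoxicity, read by MTT assay, with a stated time of 24 h (on this read-out higher numbers stand for weaker inhibition and lower numbers for stronger inhibition), these two stand within the scatter of each other, so compound 2 has no measured neighbour clearly apart from it. Compound 3 `O=C1/C(=C/c2cccnc2)CN(S(=O)(=O)c2ccccc2)C/C1=C\c1ccccc1C(F)(F)F` is not yet measured and carries phenylsulfonyl in place of hydrogen on an amine nitrogen in a ring, counted as phenylsulfonyl in place of hydrogen on an amine nitrogen in a ring in all. Among the measured compounds shown here, only one measured step bears on this nitrogen, namely a 2.0-fold higher number from compound 1 to compound 2 (0.29 log units; within the scatter) on going from methyl to hydrogen. For the measured compounds named here, no compound with phenylsulfonyl has been measured, so that step offers only weak guidance for so large a group. In this assay no step beyond the scatter is expected, and the estimated change is a 1.7-fold lower number from compound 2 to compound 3 (0.22 log units; within the scatter) with wide uncertainty. For compound 3 the estimated value is 3000 nM, with an expected range of 900 nM to 9000 nM.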

Compound 3, half-maximal inhibitory concentration: 5370 nM
Compound 3: middle estimate off by 1.8-fold (0.25 log units), on the low side; the range from low to high includes it.
By their numbers in this assay, from the lowest: compounds 1, 2 and 3 (each within the scatter of the next, the first and the last beyond it).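

In this assay the step of a 1.1-fold higher number from compound 2 to compound 3 (0.03 log units; within the scatter) stays within the scatter, so on an amine nitrogen in a ring, phenylsulfonyl with its 9 heavy atoms and hydrogen read alike, which the methyl and hydrogen pair could not show for a group of this size. Among the compounds shown here, measured against methyl, the same group gives a 2.1-fold higher number from compound 1 to compound 3 (0.32 log units; beyond the scatter) and this is the only step among the three compounds beyond the scatter, a modest one, with compound 2 within the scatter of both others. No evidence on the cause of these small steps is at hand.

Open, from the compounds shown here alone, is whether an acetyl group, a benzyl group or a longer chain on this nitrogen would read the same as phenylsulfonyl. Also open, going by these compounds, is whether a carboxylic acid or an amine on the phenyl ring of compound 3 would move the number beyond the scatter.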